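Trifluoromethyl for chloro on the arylhydrazone of compound 1

The source may report more compounds than this note shows. Statements on the series, on what has been measured and on what is new or still open speak of the compounds shown alone.

Within the data shown here, compound 1 `CC1CC/C(=N\Nc2ccc(Cl)cc2)c2ncc(C(=O)O)c(=O)n21` gives 0.5 umol/kg in a functional assay on the whole organism for inhibition, with Rattus norvegicus as the target (a higher number here means that more compound is needed for the effect, a lower number that less compound is needed), the highest of the three numbers known. Compound 2 `CC1CC/C(=N\Nc2ccccc2O)c2ncc(C(=O)O)c(=O)n21` gives 0.26 umol/kg, and compound 3 `Cc1cccc(N/N=C2\CCC(C)n3c2ncc(C(=O)O)c3=O)c1` gives 0.4 umol/kg. Compound 4 `CC1CC/C(=N\Nc2ccc(C(F)(F)F)cc2)c2ncc(C(=O)O)c(=O)n21` differs from compound 1 by trifluoromethyl in place of chloro on an aromatic carbon. Among the measured compounds shown here, the steps that bear on this change alter the same aryl group: a 1.9-fold lower number from compound 1 to compound 2 (0.28 log units; within the scatter), a 1.3-fold lower number from compound 1 to compound 3 (0.10 log units; within the scatter) and a 1.5-fold higher number from compound 2 to compound 3 (0.19 log units; within the scatter), each within the scatter. Since changing the group on this ring has so far moved the number only within the scatter, compound 4 is expected to stay near compound 1, with an estimated step of no change at the digits printed from compound 1 to compound 4 (within the scatter). Compound 4 is therefore estimated at 0.5 umol/kg, with a range from 0.2 umol/kg to 1.2 umol/kg.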

Compound 4, dose for 50% inhibition: 38.6 umol/kg
Beside the measured number, compound 4's estimate is 77-fold (1.89 log units) below it, and the stated range ends below it.
By their numbers in this assay, from the lowest: compounds 2, 3 and 1 (each within the scatter of the next); then compound 4.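

In this assay, the aromatic carbon para to a large group proves far from indifferent: with trifluoromethyl in place of chloro there, the step is a 77-fold higher number from compound 1 to compound 4 (1.89 log units; beyond the scatter). The aryl changes in compound 2 and compound 3 all stayed within the scatter, so the tolerance they suggested does not extend to this group at this place. Nothing available accounts for this step. Going by these compounds, whether a nitrile, a methoxy group or bromo at this same place would stay near compound 1 or fall near compound 4 remains open.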